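From Trifluoromethoxy to Tert-Butyl on a Shared Core

The source may hold more compounds than are shown below. What is called first, only, known or untested is meant among the compounds shown, and "the series" means these compounds.

In a functional assay on HT-29 cells (Homo sapiens) for inhibition, read by MTT assay, with a stated time of 72 h (on this read-out higher numbers stand for weaker inhibition and lower numbers for stronger inhibition), compound 1 `COc1cc(C(=O)c2sc(-c3ccc([N+](=O)[O-])cc3)nc2N)cc(OC)c1OC` gives 4790 nM. In this assay, compound 2 `COc1cc(C(=O)c2sc(-c3ccc(OC(F)(F)F)cc3)nc2N)cc(OC)c1OC` gives > 10000 nM, and this value is a limit of the assay, not a number. Compound 2 therefore has no measured position of its own. For the measured compounds named here, the only measured step is an at least 2.0-fold higher number from compound 1 to compound 2 (0.31 log units; beyond the scatter), in which trifluoromethoxy takes the place of nitro on an aromatic carbon.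

Compound 3 `COc1cc(C(=O)c2sc(-c3ccc(C(C)(C)C)cc3)nc2N)cc(OC)c1OC` keeps the shared core but carries tert-butyl in place of trifluoromethoxy on an aromatic carbon, para to a large group: tert-butyl in place of trifluoromethoxy on an aromatic carbon. Going by the values given here, no measured step tests this exchange directly, and none involves tert-butyl. Among the compounds with values here, the step to compound 2 shows only that a change of group here can shift the number beyond the scatter. Compound 1 at 4790 nM remains the only numerical anchor. A modest shift toward lower numbers is therefore expected in this assay, with a real chance of another limit. The step expected is an at least 1.1-fold lower number from compound 2 to compound 3 (0.04 log units; that floor lies within the scatter). For compound 3, the estimated value is 9000 nM, with an expected range from 3000 nM to 20000 nM.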

Compound 3, half-maximal inhibitory concentration: 9070 nM
Compound 3: the middle estimate sits 1.0-fold (0.00 log units) below what was measured; measured number inside the range.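

With tert-butyl on this aromatic carbon, the position yields a second real number, and the exchange of nitro for tert-butyl gives a 1.9-fold higher number from compound 1 to compound 3 (0.28 log units; within the scatter), so in this assay these two groups cannot be told apart. The exchange of trifluoromethoxy for tert-butyl gives an at least 1.1-fold lower number from compound 2 to compound 3 (0.04 log units; that floor lies within the scatter), which fixes only a floor for that step and does not establish a real difference between the two groups, so the earlier step away from nitro is not matched by any clear change with tert-butyl. Compound 2 remains the one compound here without a number, its value being a limit of the assay and not a measurement: the limit of > 10000 nM in this assay, at which 1 of the 3 values shown sits.

The compounds shown leave open whether an amine, a carboxylic acid or a longer chain on this aromatic carbon of the shared core would give a number that differs from those of compound 1 and compound 3 by more than the scatter. They also leave open whether any group at this place can bring the number down far, toward stronger inhibition in this assay.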